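The compounds below may be only part of what the source reports. "The series", "measured", "known", "first", "only" and "open" are said of these compounds alone.

In an ADME assay on L02 cells (Homo sapiens) for antiproliferative activity, read by MTT assay, with a stated time of 48 h (a higher number here means a weaker inhibitor, a lower number a stronger inhibitor), compound 3 `N#CC1=C(N)Oc2c(N)cc3nc4ccccc4nc3c2C12C(=O)N(Cc1cnnn1-c1ccccc1Br)c1ccccc12` gives 29200 nM, the only number among the three results shown. Compound 1 `N#CC1=C(N)Oc2c(c3nc4ccccc4nc3c3ccccc23)C12C(=O)N(Cc1cnnn1-c1cccc(S(N)(=O)=O)c1)c1ccccc12` returns the limit > 50000 nM. Compound 2 `Cc1ccc(-n2nncc2CN2C(=O)C3(C(C#N)=C(N)Oc4c3c3nc5ccccc5nc3c3ccccc43)c3ccccc32)c(C)c1` likewise returns the limit > 50000 nM. The step that the two limits leave unreadable from compound 1 to compound 2 cannot be read, and what remains is the limit of > 50000 nM in this assay, at which 2 of the 3 values shown sit. Compound 4 `COc1cc(-n2nncc2CN2C(=O)C3(C(C#N)=C(N)Oc4c(N)cc5nc6ccccc6nc5c43)c3ccccc32)c(OC)cc1Cl` differs from compound 3 by 4-chloro-2,5-dimethoxyphenyl in place of 2-bromophenyl on an aromatic nitrogen. Among the compounds with values here, no measured step concerns this change, and the one pair that was measured gives no readable size or direction. The expected step of a 1.2-fold higher number from compound 3 to compound 4 (0.08 log units; within the scatter) is accordingly placed within the usual scatter. Compound 4 is estimated at 35000 nM, with a range from 15000 nM to 80000 nM, and it may also end at the limit of the assay.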

Compound 4, half-maximal inhibitory concentration: > 50000 nM
Compound 4 gave a limit, no number; the forecaster's own chance of this, stated with the estimate: 40%; middle value at least 1.4-fold (0.15 log units) away from the limit.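

Unlike the step between compound 1 and compound 2, which cannot be read, this change on the aromatic nitrogen gives a step with a direction: in this assay there is an at least 1.7-fold higher number from compound 3 to compound 4 (0.23 log units; that floor lies within the scatter). Compound 4 gave a limit and not a number, so only that floor is known. Most of the results now stand at one point: the limit of > 50000 nM in this assay, at which 3 of the 4 values shown sit.

The compounds shown do not separate the chlorine from the two methoxy groups. On these data alone, how a plain phenyl or a 4-aminophenyl group would read at this position remains open.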